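Ester chain variation and tolerated concentration in a shared-core series

The source may hold more compounds than are shown below. What is called first, only, known or untested is meant among the compounds shown, and "the series" means these compounds.

Measured so far:
compound 1 `Nc1ncnc2c1ncn2CC(O)C(=O)OCCO`: > 400 ug/mL
compound 2 `COCCOC(=O)C(O)Cn1cnc2c(N)ncnc21`: > 400 ug/mL
compound 3 `CCCOC(=O)C(O)Cn1cnc2c(N)ncnc21`: 100 ug/mL

In a functional assay on PRK cells (Oryctolagus cuniculus) for cytotoxicity (a lower number here means that less compound is tolerated, a higher number that more compound is tolerated), compound 1 gives > 400 ug/mL, which is a limit of the assay and not a number. Compound 2 likewise gives > 400 ug/mL, again a limit. Among the compounds with values here, compound 3 gives 100 ug/mL, the only number among the three. For compound 3 less is thus tolerated than for the other two, whose values both sit at the limit of > 400 ug/mL in this assay, at which 2 of the 3 values shown sit. The step of an at least 4.0-fold lower number from compound 1 to compound 3 (0.60 log units; beyond the scatter) and the step of an at least 4.0-fold lower number from compound 2 to compound 3 (0.60 log units; beyond the scatter) both run in the same direction, while a step that the two limits leave unreadable from compound 1 to compound 2.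

Compound 4 `CC(C)COC(=O)C(O)Cn1cnc2c(N)ncnc21` is not yet measured in this assay. It differs from compound 3 by methyl in place of hydrogen on a saturated chain carbon bound to two saturated chain carbons. Within the data shown here, none of the measured steps concerns a change of this kind: they exchange hydroxy or methoxy for methyl, or hydrogen for methyl on an oxygen, whereas here a methyl enters on a chain carbon. The measured steps therefore give no direct guide, and a step of modest size at most is expected, in either direction or none beyond the scatter. For compound 4 in this assay a value of 70 ug/mL is expected, between 25 ug/mL and 200 ug/mL. The step that this estimate means is expected to be a 1.4-fold lower number from compound 3 to compound 4 (0.15 log units; within the scatter).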

Compound 4, minimum cytotoxic concentration: > 400 ug/mL
Compound 4: only a limit was reported (the forecaster's own chance of this, stated with the estimate: 5%); at least 5.7-fold (0.75 log units) between middle value and limit.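

In this assay the change from propoxy to isobutoxy adds one methyl on a saturated chain carbon bound to two saturated chain carbons, and it gives an at least 4.0-fold higher number from compound 3 to compound 4 (0.60 log units; beyond the scatter). Compound 4 gives > 400 ug/mL, which is a limit of the assay and not a number. The lower number of compound 3 therefore does not follow from an ester chain of carbon alone, since compound 4 also carries such a chain and goes against that reading: the limit of > 400 ug/mL in this assay, at which 3 of the 4 values shown sit.

The steps from compound 1 and from compound 2 to compound 4 cannot be read, as both ends of each are limits. Open, as far as these compounds go, is how the tolerated concentration responds to a longer chain such as pentyl, or to an amine or a carboxylic acid in the ester chain.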